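The source may report more compounds than this note shows. Statements on the series, on what has been measured and on what is new or still open speak of the compounds shown alone.

Compound 1 `CC(CC(=N)S)n1ncccc1=O` in a functional assay on the whole organism (stomach) for inhibition, with Rattus norvegicus as the target, at a dose of 100 mg/kg by the intraduodenal route (a higher number here means more inhibition at the dose given (going by the name of the read-out), a lower number less inhibition), gives 38.8%. Compound 2 `CC(CC(=N)S)n1nc(-c2ccccc2)ccc1=O` in this assay gives 15.5%, the lower of the two numbers measured. Among the measured compounds shown here, the only measured step is a number 23.3 percentage points lower from compound 1 to compound 2 (beyond the scatter), phenyl in place of hydrogen on an aromatic carbon. Compound 3 `Cc1ccc(=O)n(C(C)CC(=N)S)n1` differs from compound 2 by methyl in place of phenyl on an aromatic carbon. For the measured compounds named here, no measured step exchanges phenyl for methyl; a partial recovery of inhibition is expected because a number 23.3 percentage points lower from compound 1 to compound 2 (beyond the scatter) shows the phenyl carrying the loss. For compound 3 the expected step is a number 14.5 percentage points higher from compound 2 to compound 3 (beyond the scatter), upward with wide uncertainty. Compound 3 is estimated at 30%, with a range from 12% to 48%.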

Compound 3, a percentage reported as inhibition, in the whole organism at one dose (the size of the read-out at that dose, not a potency): 32.5%
Estimate against measurement, compound 3: 2.5 percentage points below, and the stated range covers the measured number.
By their numbers in this assay, from the lowest: compound 2; then compounds 3 and 1 (each within the scatter of the next).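

In this assay, methyl on this aromatic carbon stays close to hydrogen, with a number 6.3 percentage points lower from compound 1 to compound 3 (within the scatter) and a number 17 percentage points higher from compound 2 to compound 3 (beyond the scatter). The loss seen with phenyl therefore does not extend to every replacement of hydrogen at this position, at least among the three groups shown. Nothing available explains the difference between methyl and phenyl here.

On these data alone, whether an ethyl chain, a methoxy group or an amine at this position would stay with methyl or fall with phenyl remains open. As far as these compounds go, whether methyl behaves the same way elsewhere on the ring is also open.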